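The source may report more compounds than this note shows. Statements on the series, on what has been measured and on what is new or still open speak of the compounds shown alone.

Compound 1 `C=C(Br)C(=O)Nc1cccc(-c2cn3nc(-c4ccc(OC)c(OC)c4)sc3n2)c1`: 110 nM
Compound 2 `COc1cccc(-c2nn3cc(-c4cccc(N)c4)nc3s2)c1`: 29000 nM
Compound 3 `C=C(Br)C(=O)Nc1cccc(-c2cn3c(-c4ccc(OC)cc4)csc3n2)c1`: 620 nM

All three compounds were tested in a functional assay on FM3A cells (Mus musculus) for inhibition, read by cell counting, with a stated time of 2 days; a lower number here means a stronger inhibitor, a higher number a weaker inhibitor. Compound 1 stands at the lowest number of the three, so it is the strongest inhibitor among them. Its nearest neighbour is compound 3, whose number is higher by a margin beyond the usual scatter, and compound 2 lies far higher still, also well beyond the scatter. No pair of these compounds differs in a single place, so no single-step comparison is available to guide the next change.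

The untested compound is compound 4 `C=C(Br)C(=O)Nc1cccc(-c2cn3nc(CCc4ccccc4)sc3n2)c1`. It keeps the shared core of compound 1, including the bromoacrylamide-bearing aryl group, and differs from compound 1 in one place: phenethyl in place of 3,4-dimethoxyphenyl on an aromatic carbon

Among the measured compounds shown here, nothing measured so far shows this kind of change, so the expectation rests on the general observation that the group leaving is part of what makes compound 1 the lowest number here. A modest loss of potency, beyond the scatter, is expected rather than a gain. Compound 4 is therefore estimated to give about 400 nM, with a range from 120 nM to 1500 nM. This estimate corresponds to an expected step of a 3.6-fold higher number from compound 1 to compound 4 (0.56 log units; beyond the scatter).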

Compound 4, half-maximal inhibitory concentration: 2600 nM
The estimate for compound 4 lay 6.5-fold (0.81 log units) below the measured number; measured number above the stated range.
By their numbers in this assay, from the lowest: compound 1; then compound 3; then compound 4; then compound 2.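

In this assay, putting phenethyl in place of 3,4-dimethoxyphenyl on this aromatic carbon gives a 24-fold higher number from compound 1 to compound 4 (1.37 log units; beyond the scatter), the first direct sign that the group at this position strongly affects the number. Both groups carry one six-membered aromatic ring of carbon only, so the presence of such a ring here does not by itself preserve the number of compound 1. The change also removes both oxygen atoms and the hydrogen-bond acceptors counted in the leaving group, but no measurement here explains the loss.

Because this single swap alters both the ring's substituents and how the ring is attached, the compounds shown cannot separate the contribution of the methoxy groups from that of the phenethyl chain. A plain phenyl group or a benzyl group on the same carbon would help pull these apart, while an amine or a carboxylic acid there would test whether this position accepts a group of a quite different kind.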